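A few compounds are considered here, and "the series" means these few. Any claim that something is new, unique, unknown or untested is made for them only; others in the source may bear on it.

Measured so far:
- compound 1, `COc1ccccc1-c1cnc(C(=O)CCCCCCc2ccccc2)o1`, 400 nM in an assay (Rattus norvegicus) for inhibition of Fatty-acid amide hydrolase 1 (Homo sapiens); a higher number here means a weaker inhibitor, a lower number a stronger inhibitor
- compound 2, `Cc1cccc(-c2cnc(C(=O)CCCCCCc3ccccc3)o2)n1`, 3.3 nM in this assay
- compound 3, `CN1CCN(C(=O)c2cnc(C(=O)CCCCCCc3ccccc3)o2)CC1`, 80 nM in this assay

Compound 3 stands second highest of the three numbers. Its nearest neighbour is compound 1, with a 5.0-fold lower number from compound 1 to compound 3 (0.70 log units; beyond the scatter); its furthest is compound 2, with a 24-fold higher number from compound 2 to compound 3 (1.38 log units; beyond the scatter). All three compounds share one core and differ only in the group carried on the same aromatic carbon.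

Compound 4, `O=C(CCCCCCc1ccccc1)c1ncc(F)o1`, has not yet been measured in this assay. It differs from compound 3 in a single place: fluoro in place of (4-methylpiperazin-1-yl)carbonyl on an aromatic carbon.

Every measured step swaps the group at that position, so all three bear on this change. Two of them were large, a 120-fold lower number from compound 1 to compound 2 (2.08 log units; beyond the scatter) and a 24-fold higher number from compound 2 to compound 3 (1.38 log units; beyond the scatter), and one was modest, a 5.0-fold lower number from compound 1 to compound 3 (0.70 log units; beyond the scatter). Those steps show that this position moves the number strongly, but none of them exchanges a large group for a single atom, so the direction is uncertain. Compound 4 is expected to give a higher number than compound 3, with a 7.5-fold higher number from compound 3 to compound 4 (0.88 log units; beyond the scatter) as the estimated step. Compound 4 is estimated at 600 nM, within a range of 100 nM to 4000 nM.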

Compound 4, inhibition constant: 30 nM
For compound 4 the middle estimate is 20-fold (1.30 log units) above the measured one, and the stated range ends above it.
By their numbers in this assay, from the lowest: compound 2; then compound 4; then compound 3; then compound 1.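

A single fluoro on this aromatic carbon holds up well in this assay, with no ring and no hydrogen-bond acceptors in the group (a 2.7-fold lower number from compound 3 to compound 4 (0.43 log units; beyond the scatter)), so the (4-methylpiperazin-1-yl)carbonyl group is not needed for a number in this range. The fluoro compound also does better than the 2-methoxyphenyl compound (a 13-fold lower number from compound 1 to compound 4 (1.12 log units; beyond the scatter)), yet it does not reach the 6-methylpyridin-2-yl compound (a 9.1-fold higher number from compound 2 to compound 4 (0.96 log units; beyond the scatter)). The heavy-atom count of the group therefore does not by itself order these four compounds, since the smallest group falls between the two groups that carry an aromatic ring.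

Nothing available here explains why the groups rank in this order. As far as these compounds go, what chloro, a nitrile or a plain hydrogen on this carbon would give remains open, and so does whether fluoro itself matters or any very small group would serve.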